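A few compounds are considered here, and "the series" means these few. Any claim that something is new, unique, unknown or untested is made for them only; others in the source may bear on it.

Compound 1, `COC(=O)CC/C=C\CC[C@H]1C(=O)C[C@@H](O)[C@@H]1/C=C/C[C@@](C)(O)/C=C/C=C(C)C`, opens the pair of measured compounds. In a functional assay on the whole organism with Rattus norvegicus as the target (on this read-out lower numbers stand for an effect already at smaller amounts and higher numbers for an effect only at larger amounts of compound), compound 1 reaches only a limit of the assay, > 3.16 mg/kg. Compound 2, `COC(=O)CC/C=C\CC[C@H]1C(=O)C[C@@H](O)[C@@H]1/C=C/C[C@@](C)(O)/C=C/C1=CCCC1`, carries cyclopent-1-en-1-yl in place of 2-methylprop-1-en-1-yl on a double-bonded chain carbon bound to a double-bonded chain carbon. In this assay compound 2 likewise gives only a limit of the assay, > 3.16 mg/kg. The step that the two limits leave unreadable from compound 1 to compound 2 therefore cannot be read, as both values sit at the limit of > 3.16 mg/kg in this assay, at which 2 of the 2 values shown sit. Compound 2 thus stands at the limit that every value shown reaches, with nothing to rank it against. Compound 3, `C=C/C=C/[C@](C)(O)C/C=C/[C@H]1[C@H](O)CC(=O)[C@@H]1CC/C=C\CCC(=O)OC`, differs from compound 2 in one place: vinyl in place of cyclopent-1-en-1-yl on a double-bonded chain carbon bound to a double-bonded chain carbon. Among the compounds with values here, only the step from compound 1 to compound 2 bears on this change, and its size is not readable, so no direction can be set for compound 3 in this assay beyond the scatter. Compound 3 is estimated at 5 mg/kg, within 1.5 mg/kg to 30 mg/kg. The step this estimate means, a step that the limit leaves unreadable from compound 2 to compound 3, is expected to stay small.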

Compound 3, dose for half-maximal effect: 0.243 mg/kg
Estimate against measurement, compound 3: 21-fold (1.31 log units) above; measured number outside the range, below it.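

In this assay, the group at this place on a double-bonded chain carbon bound to a double-bonded chain carbon does make a difference: vinyl in place of cyclopent-1-en-1-yl gives an at least 13-fold lower number from compound 2 to compound 3 (1.11 log units; beyond the scatter), and vinyl in place of 2-methylprop-1-en-1-yl gives an at least 13-fold lower number from compound 1 to compound 3 (1.11 log units; beyond the scatter). The earlier pair gave no reading of this place, as its two members rest at the same limit of the assay: the limit of > 3.16 mg/kg in this assay, at which 2 of the 3 values shown sit. Of the three groups shown, only vinyl gives a measured dose rather than a limit, so the two larger-looking end groups can now be set against a real number, though not against each other.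

The step between compound 1 and compound 2 still cannot be read, and the compounds shown do not separate the loss of the ring in compound 2 from the loss of the two methyl groups in compound 1 as the change that counts. As far as these compounds go, whether an ethyl group, a prop-1-en-1-yl group or a plain hydrogen at this place would keep the low dose of compound 3 remains open.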